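This account rests on a few compounds, and the source may have more. Where it says the series, first, only, none or still open, it means among the compounds named here.

Measured compounds:
compound 1 `COc1cc(Oc2cccc(Nc3ccccc3)c2)cc(OC)c1CNCc1ccc(F)cc1` — 3640 nM in a functional assay on HCT-15 cells (Homo sapiens) for inhibition, read by MTT assay, with a stated time of 72 h; a lower number here means a stronger inhibitor, a higher number a weaker inhibitor
compound 2 `CNCc1c(OC)cc(Oc2cccc(Nc3ccccc3)c2)cc1OC` — 8930 nM in this assay
compound 3 `COc1cc(Oc2cccc(Nc3ccccc3)c2)cc(OC)c1CNCc1ccc(Cl)cc1` — 4850 nM in this assay

Compound 3 sits close to both others: a 1.3-fold higher number from compound 1 to compound 3 (0.12 log units; within the scatter) and a 1.8-fold lower number from compound 2 to compound 3 (0.27 log units; within the scatter), so neither gap separates it from its neighbours. The shared core carries a secondary amine, and what sits on the saturated chain carbon bound to that nitrogen is the only thing that varies. Compound 4 `COc1ccc(CCCNCc2c(OC)cc(Oc3cccc(Nc4ccccc4)c3)cc2OC)cc1` changes this position again: 2-(4-methoxyphenyl)ethyl in place of 4-chlorophenyl on a saturated chain carbon bound to an amine nitrogen. Among the measured compounds shown here, two measured steps bear on it. Removing the aryl group altogether gave a 2.5-fold higher number from compound 1 to compound 2 (0.39 log units; beyond the scatter), a modest loss, while putting a 4-chlorophenyl back gave a 1.8-fold lower number from compound 2 to compound 3 (0.27 log units; within the scatter). For the measured compounds named here, a substituted phenyl on this carbon therefore seems worth a small amount, and compound 4 keeps a phenyl, though moved further out along a longer chain; no measured step tests that lengthening. In this assay the expected change is a 1.2-fold lower number from compound 3 to compound 4 (0.08 log units; within the scatter), nothing beyond the scatter. Compound 4 is estimated at 4000 nM, within a range from 1500 nM to 12000 nM.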

Compound 4, half-maximal inhibitory concentration: 730 nM
Estimate against measurement, compound 4: 5.5-fold (0.74 log units) above, and the stated range ends above it.
By their numbers in this assay, from the lowest: compound 4; then compounds 1, 3 and 2 (each within the scatter of the next, the first and the last beyond it).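

Putting 2-(4-methoxyphenyl)ethyl in place of 4-chlorophenyl on this saturated chain carbon bound to an amine nitrogen gave a 6.6-fold lower number from compound 3 to compound 4 (0.82 log units; beyond the scatter) in this assay, and in place of 4-fluorophenyl it gave a 5.0-fold lower number from compound 1 to compound 4 (0.70 log units; beyond the scatter). Measured against hydrogen at the same place, the change gave a 12-fold lower number from compound 2 to compound 4 (1.09 log units; beyond the scatter), so this position can shift the number much further than the earlier compounds, which spanned only a modest step, had shown. Nothing available here accounts for the size of this gain.

The longer chain and the methoxy group in place of a halogen arrive together in this one change, and the compounds shown do not separate them. A 2-(4-chlorophenyl)ethyl or an unsubstituted 2-phenylethyl group at this place would be needed to tell which of the two carries the gain.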